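Chain variation on the shared core: sulfur out, branch in

The compounds below may be only part of what the source reports. "The series", "measured", "known", "first", "only" and "open" are said of these compounds alone.

Compound 1 `CCNCCn1c(N2CCN(C)CC2)nc2ccccc21` gives 290 nM in a functional assay on ileum for inhibition of histamine H1 receptor (Cavia porcellus); a higher number here means a weaker inhibitor, a lower number a stronger inhibitor. Compound 2 `CCSCCCn1c(N2CCN(C)CC2)nc2ccccc21` gives 530 nM in this assay and sits alongside compound 1 within the scatter, as the step of a 1.8-fold higher number from compound 1 to compound 2 (0.26 log units; within the scatter) shows. Compound 3 `CCCC(C)Cn1c(N2CCN(C)CC2)nc2ccccc21` carries 1-methylbutyl in place of 2-(ethylsulfanyl)ethyl on a saturated chain carbon bound to an aromatic nitrogen. Within the data shown here, the one measured step bearing on the chain, a 1.8-fold higher number from compound 1 to compound 2 (0.26 log units; within the scatter), swapped an amino for a sulfur without moving beyond the scatter; now the sulfur leaves and only carbon enters, for which no direct precedent exists. For compound 3 the expected step is a 1.1-fold higher number from compound 2 to compound 3 (0.05 log units; within the scatter), nothing clearly beyond the scatter. Compound 3 is estimated at 600 nM, with a range from 250 nM to 1500 nM.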

Compound 3, half-maximal inhibitory concentration: 500 nM
Estimate against measurement, compound 3: 1.2-fold (0.08 log units) above; the measured number falls inside the stated range.
By their numbers in this assay, from the lowest: compounds 1, 3 and 2 (each within the scatter of the next).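

Replacing 2-(ethylsulfanyl)ethyl with 1-methylbutyl, which has no sulfur and no hydrogen-bond acceptor, gives a 1.1-fold lower number from compound 2 to compound 3 (0.03 log units; within the scatter) in this assay so at this place on a saturated chain carbon bound to an aromatic nitrogen, the all-carbon branched chain stays within the scatter of the sulfur chain. The comparison with the amino chain gives a 1.7-fold higher number from compound 1 to compound 3 (0.24 log units; within the scatter) which also leaves the two chains unseparated. Nothing available accounts for this tolerance.

Going by these compounds, whether a longer chain, a phenyl ring or a carboxylic acid at this place would move the number beyond the scatter remains open.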